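The source may report more compounds than this note shows. Statements on the series, on what has been measured and on what is new or still open speak of the compounds shown alone.

Compound 1 `CC(C)=CCC[C@H](C)c1ccc(C)cc1O`: in an ADME assay on MDA-MB-231 cells (Homo sapiens) for inhibition, read by MTT assay, with a stated time of 24 h (on this read-out higher numbers stand for weaker inhibition and lower numbers for stronger inhibition), compound 1 gives > 20000 nM, a limit of the assay.
Compound 2 `CC(C)=CCC[C@H](C)c1ccc(C)c(CNCCO)c1O`: in this assay compound 2 gives > 20000 nM, a limit of the assay.
Compound 3 `CC(C)=CCC[C@H](C)c1ccc(C)c2c1OCN(CC1CCNCC1)C2`: in this assay compound 3 gives > 20000 nM, a limit of the assay.

Compound 2 stands at the limit of > 20000 nM in this assay, at which 3 of the 3 values shown sit, with no number of its own. The step that the two limits leave unreadable from compound 1 to compound 2 is not readable, as both ends are limits. Compound 4 `CC(C)=CCC[C@H](C)c1ccc(C)c(CNCC2CCNCC2)c1O` differs from compound 2 by piperidin-4-yl in place of hydroxymethyl on a saturated chain carbon bound to an amine nitrogen. Within the data shown here, no measured step bears on this change, and every value in this assay so far is a limit, so there is nothing to read a direction from. Compound 4 is expected to give 25000 nM in this assay, between 10000 nM and 60000 nM. The expected step that the limit leaves unreadable from compound 2 to compound 4 is none beyond the scatter, most likely another limit.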

Compound 4, half-maximal inhibitory concentration: > 20000 nM
Compound 4: only a limit was reported; the forecaster's own chance of this, stated with the estimate: 80%; the middle value does not contradict the limit.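

No step can be read between compound 2 and compound 4, because both results are limits: the limit of > 20000 nM in this assay, at which 4 of the 4 values shown sit.

The compounds shown leave open which change to the shared core, if any, would give a readable value in this assay.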